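Methoxy in place of isopropyl on a weak inhibitor

This account rests on a few compounds, and the source may have more. Where it says the series, first, only, none or still open, it means among the compounds named here.

Compound 1 `Cc1cnc(Nc2ccc(C(C)C)cc2)nc1Nc1nc2ccccc2s1` is one of three compounds tested in a functional assay on MDA-MB-231 cells (Homo sapiens) for antiproliferative activity, read by MTT assay, with a stated time of 48 h; a higher number here means a weaker inhibitor, a lower number a stronger inhibitor. For compound 1 the result is only a limit, > 50000 nM, not a number. Compound 2 `Cc1cnc(Nc2ccc(S(C)(=O)=O)cc2)nc1Nc1nc2ccc(F)cc2s1` likewise reaches only a limit, > 50000 nM. Compound 3 `CS(=O)(=O)c1ccc(Nc2nccc(Nc3nc4ccccc4s3)n2)cc1` gives 5910 nM. So compound 1 stands at the limit of > 50000 nM in this assay, at which 2 of the 3 values shown sit, with compound 3 the single value inside the measurable range. Compound 4 `COc1ccc(Nc2ncc(C)c(Nc3nc4ccccc4s3)n2)cc1` is not yet measured and differs from compound 1 by methoxy in place of isopropyl on an aromatic carbon. Within the data shown here, no measured pair isolates this change, so neither size nor direction of the step is known from the data. Because compound 1 sits at the limit of > 50000 nM in this assay, at which 2 of the 3 values shown sit, compound 4 is expected to give about 35000 nM, somewhere between 6000 nM and 50000 nM. That estimate implies a step of an at least 1.4-fold lower number from compound 1 to compound 4 (0.15 log units; that floor lies within the scatter).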

Compound 4, half-maximal inhibitory concentration: > 50000 nM
Compound 4: no number, only a limit; the forecaster's own chance of this, stated with the estimate: 55%; at least 1.4-fold (0.15 log units) between middle value and limit.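

In this assay, among these compounds, compound 1 and compound 4 each give only a limit, not a number, so no step between them can be read. Going by these compounds, whether isopropyl or methoxy gives the stronger inhibitor stays open. Both results sit at the same limit: the limit of > 50000 nM in this assay, at which 3 of the 4 values shown sit.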